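A few compounds are considered here, and "the series" means these few. Any claim that something is new, unique, unknown or untested is made for them only; others in the source may bear on it.

Values so far in a functional assay on P388 cells (Mus musculus) for cytotoxicity; a lower number here means that less compound is needed, a higher number that more compound is needed for the effect:
- compound 1 (`c1ccc(COc2cc(-c3ccccc3)nc3ccccc23)cc1`) gives > 10 ug/mL as a limit
- compound 2 (`Oc1ccc2c(O)cc(-c3ccccc3)nc2c1`) gives 0.81 ug/mL as a number
- compound 3 (`COc1ccc2nc(-c3ccccc3)cc(O)c2c1`) gives 0.33 ug/mL as a number

Compound 1 stands at > 10 ug/mL in this assay and this is a limit, not a number.

Among the compounds with values here, compound 2 at 0.81 ug/mL and compound 3 at 0.33 ug/mL are the only true numbers. Neither compound differs from compound 1 in one place, so neither gives a measured step to work from.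

Compound 4 (`CCCCOc1cc(-c2ccccc2)nc2ccccc12`) is the next to be read. It carries propyl in place of phenyl on a saturated chain carbon bound to an oxygen on an aromatic ring, which can also be read as benzyl to butyl or benzyloxy to butoxy. The rest of the core of compound 1 is kept.

Within the data shown here, with no measured step for this change, only a modest shift towards a lower number is expected in this assay, and there may be none beyond the scatter. A reading of compound 4 at the limit would be no surprise. The expected step is an at least 1.1-fold lower number from compound 1 to compound 4 (0.04 log units; that floor lies within the scatter) and should be treated as a rough estimate. Compound 4 is expected at 9 ug/mL within an estimated range of 3 ug/mL to 25 ug/mL as the working figure.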

Compound 4, half-maximal effective concentration: > 10 ug/mL
Compound 4 gave a limit, no number (the forecaster's own chance of this, stated with the estimate: 55%); middle value at least 1.1-fold (0.04 log units) away from the limit.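

In this assay compound 4 gives > 10 ug/mL, which is a limit and not a number. No step from compound 1 to compound 4 can be read, because both compounds stand at the same limit: the limit of > 10 ug/mL in this assay, at which 2 of the 4 values shown sit.

The compounds shown leave open whether benzyloxy to butoxy changes the read-out at all, since neither compound has a true number.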